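The compounds below may be only part of what the source reports. "The series", "measured", "known", "first", "only" and "open" are said of these compounds alone.

In an ADME assay on L6 cells (Rattus norvegicus) for cytotoxicity (on this read-out higher numbers stand for weaker inhibition and lower numbers for stronger inhibition), the ester compound 1 (`C/C=C(/C)C(=O)OC(C)c1cc2c(cc1OC)OC(C)(C)C=C2`) gives 139000 nM as its reading. The amine compound 2 (`COc1ccc(CNC(C)c2cc3c(cc2OC)OC(C)(C)C=C3)cc1`) gives 14900 nM and the amine compound 3 (`COc1cc2c(cc1C(C)NC/C=C/c1ccccc1)C=CC(C)(C)O2`) gives 14600 nM on the same scale. Compound 3 therefore stands level with compound 2, and both numbers lie below that of compound 1 by more than the scatter.

The next compound, compound 4 (`CCCCNC(C)c1cc2c(cc1OC)OC(C)(C)C=C2`), has not yet been measured. It differs from compound 3 by propyl in place of 2-phenylethenyl on a saturated chain carbon bound to an amine nitrogen in the amine side chain, with propyl in place of 2-phenylethenyl on a saturated chain carbon bound to an amine nitrogen. Within the data shown here, only one measured step bears on this change. That step is a 1.0-fold lower number from compound 2 to compound 3 (0.01 log units; within the scatter) and it exchanges 4-methoxyphenyl for 2-phenylethenyl at the same place without moving the number beyond the scatter.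

Among the measured compounds shown here, both groups in that step carry an aromatic ring, whereas propyl has none, so no measured step shows what losing the ring does. A small change is therefore expected, leaning towards a higher number but not beyond the scatter. The estimate amounts to a 1.5-fold higher number from compound 3 to compound 4 (0.18 log units; within the scatter) as the expected step in this assay for this exchange. For compound 4 the expected value is 22000 nM within an estimated range of 9000 nM to 50000 nM in this read-out.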

Compound 4, half-maximal inhibitory concentration: 52500 nM
Estimate against measurement, compound 4: 2.4-fold (0.38 log units) below, and the stated range ends below it.
By their numbers in this assay, from the lowest: compounds 3 and 2 (each within the scatter of the next); then compound 4; then compound 1.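

In this assay, among these compounds, exchange at this saturated chain carbon bound to an amine nitrogen now moves the number beyond the scatter, with a 3.6-fold higher number from compound 3 to compound 4 (0.56 log units; beyond the scatter) and a 3.5-fold higher number from compound 2 to compound 4 (0.55 log units; beyond the scatter), so 2-phenylethenyl and 4-methoxyphenyl, which stood level with each other, both give lower numbers than propyl, the one group of the three without an aromatic ring. The ring-free amine side chain still keeps its number under that of the ester, with a 2.6-fold lower number from compound 1 to compound 4 (0.42 log units; beyond the scatter), so an aromatic ring on the chain is not needed for compound 4 to stand apart from compound 1 beyond the scatter. Nothing measured on these compounds gives a reason for either shift.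

The compounds shown do not separate the loss of the aromatic ring from the drop in heavy atoms, a question that a cyclohexylmethyl group or an equally sized open chain such as octyl on the amine nitrogen would bear on. They also leave open how an unsubstituted benzyl group or a chain ending in a hydroxyl group or a carboxylic acid would read at this place.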